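This account rests on a few compounds, and the source may have more. Where it says the series, first, only, none or still open, it means among the compounds named here.

Of the compounds shown here, two have been measured so far. Compound 1 `CCOc1ccc(-c2cc3c(ncn3CCCN(C)C)c(C#N)n2)cc1C(F)(F)F` gives 260 nM in an assay on JY cells for inhibition of cathepsin S (Homo sapiens), read by Western blot (a lower number here means a stronger inhibitor, a higher number a weaker inhibitor), while compound 2 `Cn1cnc2c(C#N)nc(-c3ccc(OCCN4CCCC4=O)c(C(F)(F)F)c3)cc21` gives 1420 nM in this assay, the higher of the two numbers, and the gap between them lies beyond the usual scatter. Compound 3 `CN(C)CCCOc1ccc(-c2cc3c(ncn3C)c(C#N)n2)cc1C(F)(F)F` differs from compound 2 in one place: (dimethylamino)methyl in place of 2-oxopyrrolidin-1-yl on a saturated chain carbon, two bonds along the chain from an oxygen on an aromatic ring. For the measured compounds named here, no measured pair shows this same change, so its effect is not known directly. Since a 3-(dimethylamino)propyl group also appears in compound 1 with 260 nM, compound 3 is expected to move toward a lower number, with the step from compound 2 to compound 3 estimated at a 3.6-fold lower number from compound 2 to compound 3 (0.55 log units; beyond the scatter). The estimate for compound 3 is 400 nM, within 150 nM to 1200 nM.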

Compound 3, half-maximal inhibitory concentration: 84 nM
Beside the measured number, compound 3's estimate is 4.8-fold (0.68 log units) above it, and the stated range ends above it.
By their numbers in this assay, from the lowest: compound 3; then compound 1; then compound 2.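

At this place, on a saturated chain carbon two bonds along the chain from an oxygen on an aromatic ring, replacing 2-oxopyrrolidin-1-yl with (dimethylamino)methyl gives a 17-fold lower number from compound 2 to compound 3 (1.23 log units; beyond the scatter). For the compounds shown here, this is the first direct reading of the change, and it shows that this group alone can move the number well beyond the scatter. Nothing measured here accounts for the size of the step. Still open, going by these compounds, is how a morpholine, a primary amine or a carboxylic acid would fare at the end of this chain. On these data alone, a longer chain is equally open.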